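Chain extension from compound 3 to compound 4

The compounds below may be only part of what the source reports. "The series", "measured", "known", "first", "only" and "open" are said of these compounds alone.

In a functional assay on HeLa cells (Homo sapiens) for antiproliferative activity (a higher number here means a weaker inhibitor, a lower number a stronger inhibitor), compound 1 `C/C1=C\[C@@H](O)C(=O)/C=C/C=C/c2csc(n2)[C@@H](C)N2C(=O)C[C@@]([C@@](C)(O)C(=O)SCc3oc(=O)oc3C)(CC1)[S+]2[O-]` gives 4.6 nM and compound 2 `C/C1=C\[C@@H](OC(=O)CNC(=O)OCc2ccccc2)C(=O)/C=C/C=C/c2csc(n2)[C@@H](C)N2C(=O)C[C@@]([C@@](C)(O)C(=O)SCc3oc(=O)oc3C)(CC1)[S+]2[O-]` gives 4 nM, two values within the scatter of each other. Compound 3 `C/C1=C\[C@@H](OC(=O)CNC(=O)CNC(=O)OCc2ccccc2)C(=O)/C=C/C=C/c2csc(n2)[C@@H](C)N2C(=O)C[C@@]([C@@](C)(O)C(=O)SCc3oc(=O)oc3C)(CC1)[S+]2[O-]` gives 15 nM, the highest number of the three and beyond the scatter from both others, which makes it the weakest of the set so far.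

Compound 4 `C/C1=C\[C@@H](OC(=O)CNC(=O)CCNC(=O)OCc2ccccc2)C(=O)/C=C/C=C/c2csc(n2)[C@@H](C)N2C(=O)C[C@@]([C@@](C)(O)C(=O)SCc3oc(=O)oc3C)(CC1)[S+]2[O-]` differs from compound 3 by ((benzyloxycarbonyl)amino)methyl in place of (benzyloxycarbonyl)amino on a saturated chain carbon bound to a carbonyl carbon, with ((benzyloxycarbonyl)amino)methyl in place of (benzyloxycarbonyl)amino on a saturated chain carbon bound to a carbonyl carbon.

Among the compounds with values here, only one measured step bears on this change: a 3.8-fold higher number from compound 2 to compound 3 (0.57 log units; beyond the scatter), a modest move with ((benzyloxycarbonyl)amino)methyl in place of benzyloxy on a carbonyl carbon. The same group enters there, but what it replaces differs, and a single step sets no trend. No measurement of the present change exists in the series.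

The expectation therefore starts from compound 3 at 15 nM and allows for a move of the size seen in a 3.8-fold higher number from compound 2 to compound 3 (0.57 log units; beyond the scatter), in either direction. The expected change is a 1.1-fold higher number from compound 3 to compound 4 (0.03 log units; within the scatter), which would lie within the scatter. Compound 4 is estimated at 16 nM, with an expected range of 7 nM to 38 nM.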

Compound 4, half-maximal inhibitory concentration: 11 nM
For compound 4 the middle estimate is 1.5-fold (0.16 log units) above the measured one; the range from low to high includes it.
By their numbers in this assay, from the lowest: compounds 2 and 1 (each within the scatter of the next); then compounds 4 and 3 (each within the scatter of the next).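

In this assay, a 1.4-fold lower number from compound 3 to compound 4 (0.13 log units; within the scatter) when ((benzyloxycarbonyl)amino)methyl stands in place of (benzyloxycarbonyl)amino on a saturated chain carbon bound to a carbonyl carbon. Within the data shown here, the only earlier step with this entering group, a 3.8-fold higher number from compound 2 to compound 3 (0.57 log units; beyond the scatter), lay beyond the scatter, but there the group replaced benzyloxy on a carbonyl carbon, so the new result shows that its entry does not carry a shift of that size to every place in the chain; at this place, the read-out gives no separation between the two compounds. No measured evidence accounts for the difference between the two steps, and two steps with different leaving groups set no trend.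

Still open, going by these compounds, is whether a longer chain at this place would also stay within the scatter of compound 4, or whether the limit of this change lies only a little further along. Also open is what a free primary amine or a carboxylic acid at the chain end would do in place of the benzyloxycarbonyl-capped terminus, since every acylated compound shown here carries that cap.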